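The compounds below may be only part of what the source reports. "The series", "measured", "known", "first", "only" and "open" are said of these compounds alone.

Measured compounds: compound 1, `COc1ccccc1/C=C(/SCc1ccc(Cl)cc1)C(=O)c1ccc(Cl)cc1`, which gives 1000 nM in a functional assay on DU-145 cells (Homo sapiens) for inhibition, read by trypan blue exclusion, with a stated time of 96 h; a higher number here means a weaker inhibitor of growth, a lower number a stronger inhibitor of growth; compound 2, `O=C(/C(=C\c1ccc(Br)cc1)SCc1ccc(Cl)cc1)c1ccc(Cl)cc1`, which gives 1000 nM; compound 3, `COc1ccccc1/C=C(\C(=O)c1ccc(Br)cc1)S(=O)(=O)Cc1ccc(F)cc1`, which gives 25000 nM.

Compound 1 and compound 2 share a core and differ in one place: 4-bromophenyl in place of 2-methoxyphenyl on a double-bonded chain carbon bound to a double-bonded chain carbon. That change made a step of no change at the digits printed from compound 1 to compound 2 (within the scatter). Compound 3 is built on a different core; how its core differs from that of compound 1 is not broken down here. Its value sits far beyond the scatter from both compound 1 and compound 2, so the cores themselves are what separate it from them.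

Compound 4, `O=C(/C(=C\c1ccc(Br)cc1)S(=O)(=O)Cc1ccc(F)cc1)c1ccc(Br)cc1`, has not been measured. It differs from compound 3 by 4-bromophenyl in place of 2-methoxyphenyl on a double-bonded chain carbon bound to a double-bonded chain carbon, the same change that separates compound 1 from compound 2, made at the same kind of place on the second core. The expected step from compound 3 to compound 4 in this assay is no change at the digits printed from compound 3 to compound 4 (within the scatter), and it rests on the flat step seen from compound 1 to compound 2, no change at the digits printed from compound 1 to compound 2 (within the scatter). On that basis compound 4 is estimated at 25000 nM, expected to fall between 8000 nM and 80000 nM.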

Compound 4, concentration for 50% growth inhibition: 25000 nM
Compound 4: the middle estimate sits on the measured number at the digits printed; the range from low to high includes it.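

In this assay, putting 4-bromophenyl in place of 2-methoxyphenyl on the second core produced no change at the digits printed from compound 3 to compound 4 (within the scatter). Set beside the same change on the first core, the two steps agree: the same change on two cores in this assay, no change at the digits printed (within the scatter) from compound 1 to compound 2 and no change at the digits printed (within the scatter) from compound 3 to compound 4, 1.0-fold (0.00 log units) apart, within the scatter of two such steps. This shows that, in these two pairs, the flat result carried over from the core of compound 1 to the core of compound 3, but it does not show that the change would stay flat on any other core, nor does it test whether a change with a step beyond the scatter would carry over in the same way.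

The compounds shown compare only 2-methoxyphenyl and 4-bromophenyl at this place, so it remains open whether an amine, a carboxylic acid or a longer chain there would also leave the value flat. Also open is which of the differences between the two cores accounts for the gap between their values, as no pair shown isolates any one of them.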